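Extending the chain on compound 3

A few compounds are considered here, and "the series" means these few. Any claim that something is new, unique, unknown or untested is made for them only; others in the source may bear on it.

Compound 1 `CCCCCCCCCCCCNc1ccn([C@H]2C[C@H](O)[C@@H](CO)O2)c(=O)n1`: 100000 nM
Compound 2 `CCCCCCCCCCCCCCNc1ccn([C@H]2C[C@H](O)[C@@H](CO)O2)c(=O)n1`: 90000 nM
Compound 3 `CCCCCCNc1nc(=O)n([C@H]2C[C@H](O)[C@@H](CO)O2)cc1C`: 90000 nM

In an ADME assay on A549 cells (Homo sapiens) for cytotoxicity, read by MTT assay (on this read-out lower numbers stand for higher toxicity in this test and higher numbers for lower toxicity in this test), compound 3 gives 90000 nM, level with compound 2 and within the scatter of compound 1. Compound 4 `CCCCCCCCCCNc1nc(=O)n([C@H]2C[C@H](O)[C@@H](CO)O2)cc1C` carries butyl in place of hydrogen on a saturated chain carbon, six bonds along the chain from a nitrogen on an aromatic ring. Among the compounds with values here, the only measured step of this kind, a 1.1-fold lower number from compound 1 to compound 2 (0.05 log units; within the scatter), added ethyl on a saturated chain carbon and stayed within the scatter. Within the data shown here, no measured step covers butyl at this place. On that evidence, the expected change is no larger than the scatter, an estimated no change at the digits printed from compound 3 to compound 4 (within the scatter). For compound 4 the expected value is 90000 nM, with an estimated range of 50000 nM to 130000 nM.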

Compound 4, half-maximal cytotoxic concentration: 156000 nM
For compound 4 the middle estimate is 1.7-fold (0.24 log units) below the measured one, and the stated range ends below it.
By their numbers in this assay, from the lowest: compounds 2, 3, 1 and 4 (each within the scatter of the next).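

In this cytotoxicity read-out, this assay, butyl in place of hydrogen on a saturated chain carbon, six bonds along the chain from a nitrogen on an aromatic ring, gives this step: (a 1.7-fold higher number from compound 3 to compound 4 (0.24 log units; within the scatter)). Compound 4 thus shows that a chain extension of this size, at this place, also stays within the scatter, as the ethyl step did further out on a different chain. Nothing available explains the result.

From the compounds shown here alone, it remains open whether a longer chain, or an amine or a carboxylic acid at this place, would move the number beyond the scatter.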